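The source may hold more compounds than are shown below. What is called first, only, known or untested is meant among the compounds shown, and "the series" means these compounds.

Compound 1 `CCCCc1oc2ccccc2c1C(=O)c1ccc(OCC(=O)N2CCCCC2)cc1`: > 50000 nM
Compound 2 `CCCCc1oc2ccccc2c1C(=O)c1ccc(OCC(=O)N2CCOCC2)cc1`: > 50000 nM
Compound 3 `CCCCc1oc2ccccc2c1C(=O)c1ccc(OCCCC(=O)N2CCCCC2)cc1`: 36000 nM

In a functional assay on MDA-MB-231 cells (Homo sapiens) for antiproliferative activity, read by MTT assay, with a stated time of 24 h (on this read-out higher numbers stand for weaker inhibition and lower numbers for stronger inhibition), compound 1 gives > 50000 nM, which is a limit of the assay and not a number. Compound 2 gives > 50000 nM, also a limit. For the measured compounds named here, compound 3 gives 36000 nM, the only number among the three. Compound 2 differs from compound 1 by morpholin-4-yl in place of piperidin-1-yl on a carbonyl carbon; in this pair there is a step that the two limits leave unreadable from compound 1 to compound 2 because of the limit of > 50000 nM in this assay, at which 2 of the 3 values shown sit. Compound 3 differs from compound 1 by 2-((piperidin-1-yl)carbonyl)ethyl in place of (piperidin-1-yl)carbonyl on a saturated chain carbon bound to an oxygen on an aromatic ring, and the values show an at least 1.3-fold lower number from compound 1 to compound 3 (0.14 log units; that floor lies within the scatter) and an at least 1.3-fold lower number from compound 2 to compound 3 (0.14 log units; that floor lies within the scatter). Compound 4 `CCCCc1oc2ccccc2c1C(=O)c1ccc(OCCCC(=O)N2CCOCC2)cc1` is not yet measured; it differs from compound 3 by morpholin-4-yl in place of piperidin-1-yl on a carbonyl carbon, the same change, in the same place, as that from compound 1 to compound 2. Because compound 3 gives 36000 nM and the earlier instance of this change left no readable size, the expected step is small, a 1.3-fold higher number from compound 3 to compound 4 (0.10 log units; within the scatter). Compound 4 is estimated at 45000 nM, between 20000 nM and 100000 nM.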

Compound 4, half-maximal inhibitory concentration: 31600 nM
The estimate for compound 4 lay 1.4-fold (0.15 log units) above the measured number, within the range that was stated.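

In this assay morpholin-4-yl in place of piperidin-1-yl on the chain of compound 3 gives a 1.1-fold lower number from compound 3 to compound 4 (0.06 log units; within the scatter) and so no readable difference on this chain. The same change on the shorter chain cannot be sized, because both values there are limits and not numbers: the limit of > 50000 nM in this assay, at which 2 of the 4 values shown sit. The comparisons across the two chains give only an at least 1.5-fold lower number from compound 2 to compound 4 (0.19 log units; that floor lies within the scatter) and an at least 1.5-fold lower number from compound 1 to compound 4 (0.19 log units; that floor lies within the scatter) and so leave it unshown whether the change carries from one chain to the other.

Still open, as far as these compounds go, is whether another amine on the carbonyl, such as pyrrolidine, would move the number beyond the scatter. Also open, from the compounds shown here alone, is what a carboxylic acid in place of the amide, or a longer chain, would do.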